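The source may report more compounds than this note shows. Statements on the series, on what has been measured and on what is new or still open speak of the compounds shown alone.

Working notes on the series. In an assay on cells for displacement of a labelled ligand from prostaglandin E2 receptor EP4 subtype (Homo sapiens), read by scintillation counting (a higher number here means a weaker inhibitor, a lower number a stronger inhibitor), compound 3 `COc1ccccc1-c1ccc(OCc2cc(C(=O)O)oc2C)cc1` gives 1600 nM, the highest of the three numbers at hand. Compound 1 `Cc1oc(C(=O)O)cc1COc1ccc(-c2ccc(C#N)cc2)cc1` gives 1500 nM, and the step of a 1.1-fold higher number from compound 1 to compound 3 (0.03 log units; within the scatter) left the number where it was. Compound 2 `Cc1oc(CC(=O)O)cc1COc1ccc(-c2ccccc2)cc1` gives 80 nM and differs from compound 3 in two places at once, so its value can only be noted, not traced to either change.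

The next compound, compound 4 `Cc1oc(C(=O)O)cc1COc1ccc(-c2ccccc2)cc1`, differs from compound 3 as follows: hydrogen in place of methoxy on an aromatic carbon. For the measured compounds named here, the one measured step that bears on this, a 1.1-fold higher number from compound 1 to compound 3 (0.03 log units; within the scatter), exchanged the group on that same six-membered aromatic ring of carbon only and stayed within the scatter. On the evidence at hand a change of the group on this ring does not move the number in this assay, with the caveat that a single step is thin ground, and that compound 2, which also carries a plain phenyl, sits far lower while carrying a different acid.

For compound 4 a step of a 1.3-fold lower number from compound 3 to compound 4 (0.12 log units; within the scatter) is therefore expected, within the scatter. Compound 4 is estimated at 1200 nM, with a range from 400 nM to 3500 nM.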

Compound 4, inhibition constant: 420 nM
Compound 4: the middle estimate sits 2.9-fold (0.46 log units) above what was measured; the measured number falls inside the stated range.
By their numbers in this assay, from the lowest: compound 2; then compound 4; then compounds 1 and 3 (each within the scatter of the next).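

In this assay the group on this ring does matter once it is removed altogether: hydrogen in place of methoxy, ortho to a large group, gives a 3.8-fold lower number from compound 3 to compound 4 (0.58 log units; beyond the scatter), and hydrogen in place of cyano gives a 3.6-fold lower number from compound 1 to compound 4 (0.55 log units; beyond the scatter), so the plain phenyl parts from both substituted rings, although 2-methoxyphenyl and 4-cyanophenyl could not be told apart from each other. With the plain phenyl now held constant, the change of acid can also be read on its own: carboxy in place of carboxymethyl gives a 5.3-fold higher number from compound 2 to compound 4 (0.72 log units; beyond the scatter), so the shorter acid carries the higher number on this ring. Nothing at hand bears on the reason for either difference.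

The compounds shown leave open whether a smaller group on the ring, such as fluorine or methyl, would stay with the plain phenyl or join the two substituted compounds, and whether methoxy and cyano would give the same result at other places on the ring. They also leave open whether a longer chain carrying the carboxylic acid, such as carboxyethyl, would continue the difference seen with carboxymethyl, and whether that difference would hold with a substituted ring.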